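The compounds below may be only part of what the source reports. "The series", "measured", "known", "first", "only" and "open" are said of these compounds alone.

Measured so far:
compound 1, `COCCNc1nc(NCC2CC2)cc(-c2ccccn2)n1` — in a functional assay on HEK293 cells for agonist activity at G-protein coupled receptor 39 (Mus musculus), read by inositol phosphate accumulation (on this read-out lower numbers stand for an effect already at smaller amounts and higher numbers for an effect only at larger amounts of compound), compound 1 gives 10000 nM
compound 2, `CNc1nc(NCC2CCCCC2)cc(-c2ccccn2)n1` — in this assay compound 2 gives 10 nM

Compound 2 holds the lower of the two numbers; compound 1 sits far higher, well beyond the scatter. The two differ at two places at once, the cyclohexylmethyl of compound 2 against the cyclopropylmethyl of compound 1 and the methylamino against the methoxyethylamino, so neither change can be read on its own from these values.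

Compound 3, `CNc1nc(NCC2CC2)cc(-c2ccccn2)n1`, is not yet measured. It keeps the methylamino of compound 2 and carries the change (cyclopropyl in place of cyclohexyl on a saturated chain carbon bound to a nitrogen on an aromatic ring). For the measured compounds named here, compound 1, the only other compound carrying cyclopropyl on this chain, gives 10000 nM in this assay, but its second difference leaves that number unassigned. The step from compound 2 to compound 3 is expected to be a loss, a 100-fold higher number from compound 2 to compound 3 (2.00 log units; beyond the scatter), of uncertain size. Compound 3 is therefore estimated at 1000 nM, with a range of 100 nM to 10000 nM.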

Compound 3, half-maximal effective concentration: 115 nM
Compound 3: the middle estimate sits 8.7-fold (0.94 log units) above what was measured; measured number inside the range.
By their numbers in this assay, from the lowest: compound 2; then compound 3; then compound 1.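

In this assay, compound 3 separates the double difference between compound 1 and compound 2 into two single changes, and both matter. Cyclopropyl in place of cyclohexyl on a saturated chain carbon bound to a nitrogen on an aromatic ring gives a 12-fold higher number from compound 2 to compound 3 (1.06 log units; beyond the scatter), while hydrogen in place of methoxymethyl at such a place, with cyclopropylmethyl held constant, gives an 87-fold lower number from compound 1 to compound 3 (1.94 log units; beyond the scatter). Nothing measured here bears on why either change has this effect.

Open, from the compounds shown here alone, is whether intermediate or different rings on this chain, such as cyclobutyl, cyclopentyl or phenyl, fall between cyclopropyl and cyclohexyl in their numbers. Also open, going by these compounds, is how methoxyethylamino behaves alongside cyclohexylmethyl, and whether an ethyl or a longer chain in place of the methyl of the methylamino is tolerated.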